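From methoxy to methyl on compound 2

The compounds below may be only part of what the source reports. "The series", "measured", "known", "first", "only" and "open" are said of these compounds alone.

- compound 1 (`COc1cc(OC)cc(C(=O)N(CCC(=O)NCc2ccccc2)Cc2ccc(C(=O)NO)cc2)c1`) gives 6040 nM in a functional assay on IMR-32 cells (Homo sapiens) for antiproliferative activity, with a stated time of 72 h; on this read-out higher numbers stand for weaker inhibition and lower numbers for stronger inhibition
- compound 2 (`COc1ccc(C(=O)N(CCC(=O)NCc2ccccc2)Cc2ccc(C(=O)NO)cc2)cc1`) gives 1090 nM in this assay

Compound 2 has the lower of the two numbers. Compound 3 (`Cc1ccc(C(=O)N(CCC(=O)NCc2ccccc2)Cc2ccc(C(=O)NO)cc2)cc1`) carries methyl in place of methoxy on an aromatic carbon, para to a large group (methyl in place of methoxy on an aromatic carbon). Among the measured compounds shown here, the only measured guide is a modest step of a different kind, 4-methoxyphenyl in place of 3,5-dimethoxyphenyl (a 5.5-fold lower number from compound 1 to compound 2 (0.74 log units; beyond the scatter)). It shows that this part of the molecule can shift the number, but it gives no direction for the new change. In this assay no step beyond the scatter is therefore expected, and the estimated step is small (a 1.2-fold higher number from compound 2 to compound 3 (0.08 log units; within the scatter)). Compound 3 is estimated at 1300 nM with an expected range of 550 nM to 3000 nM as its span.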

Compound 3, half-maximal inhibitory concentration: 630 nM
For compound 3 the middle estimate is 2.1-fold (0.31 log units) above the measured one; the range from low to high includes it.
By their numbers in this assay, from the lowest: compounds 3 and 2 (each within the scatter of the next); then compound 1.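

In this assay methyl stands in for methoxy on this aromatic carbon without a change beyond the scatter (a 1.7-fold lower number from compound 2 to compound 3 (0.24 log units; within the scatter)), so the oxygen of the methoxy group is not required for a number in this range. The gap to the 3,5-dimethoxyphenyl compound also holds for the 4-methylphenyl group (a 9.6-fold lower number from compound 1 to compound 3 (0.98 log units; beyond the scatter)). Nothing measured here explains these numbers.

Still open, on these data alone, is how an amine, a carboxylic acid or a longer chain such as propyl on this same aromatic carbon would read in this assay.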